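This account rests on a few compounds, and the source may have more. Where it says the series, first, only, none or still open, it means among the compounds named here.

In a functional assay on K562 cells (Homo sapiens) for cytotoxicity, read by sulforhodamine B assay, with a stated time of 48 h, tested at 10 uM (on this read-out lower numbers stand for a stronger effect and higher numbers for a weaker effect at the one concentration tested), compound 2 `COc1cc(-c2cc(/C=C/C(=O)c3ccc(N)cc3)[nH]n2)cc(OC)c1OC` gives 2%, the second highest of the three numbers recorded. Compound 1 `COc1ccc(-c2cc(/C=C/C(=O)c3ccc(N)cc3)[nH]n2)cc1` gives 4% in this assay, a number within the scatter of compound 2 and one that differs from it in more than one place. Going by the values given here, compound 3 `COc1ccc(C(=O)/C=C/c2cc(-c3cc(OC)c(OC)c(OC)c3)n[nH]2)cc1` gives -17% in this assay, and the only single step recorded from compound 2 is a number 19 percentage points lower from compound 2 to compound 3 (beyond the scatter), which changes the amino group and not the methoxy pattern on the other ring.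

Compound 4 `COc1ccc(-c2cc(/C=C/C(=O)c3ccc(N)cc3)[nH]n2)cc1OC` differs from compound 2 by hydrogen in place of methoxy on an aromatic carbon. Among the compounds with values here, no recorded step concerns the loss of one methoxy group from that ring, yet compound 1, which carries only one methoxy group there, and compound 2 sit within the scatter of each other, so no shift beyond the scatter is expected from this change. Compound 4 is therefore estimated at 3% in this assay, between -12% and 18%, a step of a number 1 percentage points higher from compound 2 to compound 4 (within the scatter) that is expected to stay inside the scatter.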

Compound 4, a percentage reported as activity, at one concentration (the size of the read-out at that concentration, not a potency): 3%
Beside the measured number, compound 4's estimate shows no gap at the digits printed, and the stated range covers the measured number.
By their numbers in this assay, from the lowest: compound 3; then compounds 2, 4 and 1 (each within the scatter of the next).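

Hydrogen in place of methoxy on this aromatic carbon, ortho to a methoxy group, gives a number 1 percentage points higher from compound 2 to compound 4 (within the scatter) in this assay, and methoxy in place of hydrogen gives a number 1 percentage points lower from compound 1 to compound 4 (within the scatter). Going by these compounds alone, these are the first recorded single steps on the methoxy-bearing ring, and neither leaves the scatter, whereas the earlier single step concerned the amino group on the other ring. With that amino group kept, this read-out does not separate hydrogen from methoxy at this place, and nothing available here bears on the reason.

Going by these compounds, whether a hydroxyl group, a fluorine atom or an amine at this place would also stay within the scatter remains open. On these data alone, it is also open whether hydrogen and methoxy would stay inseparable here with methoxy in place of the amino group, as in compound 3.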